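From 3-methoxybenzyl to 4-fluorobenzyl on the amide

A few compounds are considered here, and "the series" means these few. Any claim that something is new, unique, unknown or untested is made for them only; others in the source may bear on it.

Values in a functional assay on MDA-MB-435 cells (Homo sapiens) for cytotoxicity, read by MTT assay, with a stated time of 72 h (a lower number here means a stronger inhibitor, a higher number a weaker inhibitor), so far:
- compound 1 `Nc1cccc(Nc2c(C(=O)NCc3ccc(F)cc3)nc(Br)c3cccnc23)c1` gives 8000 nM
- compound 2 `C[C@@H](Nc1c(C(=O)NCc2ccc(F)cc2)nc(Br)c2cccnc12)c1ccccc1` gives > 20000 nM as a limit
- compound 3 `COc1cccc(CNC(=O)c2nc(Br)c3cccnc3c2N[C@H]2CC[C@H](N)CC2)c1` gives 7000 nM

The reading of compound 2 is the limit of > 20000 nM in this assay, at which 1 of the 3 values shown sits, and not a number. Compound 3 at 7000 nM and compound 1 at 8000 nM lie within the scatter of each other. Compound 4 `N[C@H]1CC[C@H](Nc2c(C(=O)NCc3ccc(F)cc3)nc(Br)c3cccnc23)CC1` differs from compound 3 thus: 4-fluorophenyl in place of 3-methoxyphenyl on a saturated chain carbon bound to an amide-type nitrogen. Among the measured compounds shown here, the only measured step, an at least 2.5-fold higher number from compound 1 to compound 2 (0.39 log units; beyond the scatter), lies on a nitrogen on an aromatic ring and does not cover this place. No shift beyond the scatter is therefore expected in this assay. The expected step is a 1.2-fold lower number from compound 3 to compound 4 (0.07 log units; within the scatter) and no more. For compound 4 the estimate is 6000 nM, expected within 2500 nM to 15000 nM.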

Compound 4, half-maximal inhibitory concentration: 6000 nM
Compound 4: middle estimate and measured number agree at the digits printed; the measured number falls inside the stated range.
By their numbers in this assay, from the lowest: compounds 4, 3 and 1 (each within the scatter of the next). At a limit, above all of these: compound 2.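

At the amide, 4-fluorobenzyl for 3-methoxybenzyl gives a 1.2-fold lower number from compound 3 to compound 4 (0.07 log units; within the scatter) in this assay, so these two groups are not told apart with 4-aminocyclohexyl on the other nitrogen. With 4-fluorobenzyl held, the change on the nitrogen on the aromatic ring gives a 1.3-fold lower number from compound 1 to compound 4 (0.12 log units; within the scatter), so 4-aminocyclohexyl and 3-aminophenyl are not told apart either. Only an at least 3.3-fold lower number from compound 2 to compound 4 (0.52 log units; beyond the scatter) lies beyond the scatter, and its size is only bounded, since compound 2 is a limit: the limit of > 20000 nM in this assay, at which 1 of the 4 values shown sits.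

Open, going by these compounds, is whether a 2-phenylethyl or pyridylmethyl group on the amide would shift the number beyond the scatter. Also open, on these data alone, is whether plain cyclohexyl would match 4-aminocyclohexyl.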